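Dimethyl thiophene change tested on a second core

This account rests on a few compounds, and the source may have more. Where it says the series, first, only, none or still open, it means among the compounds named here.

Of the compounds shown here, three have been tested in a functional assay on cells (Cancer cell lines, Homo sapiens) for inhibition; a higher number here means a weaker inhibitor of growth, a lower number a stronger inhibitor of growth. Compound 1, `Cc1cc(-c2nc3sc(C)cn3c2/C=N/NC(=N)N)c(C)s1`, gives 9770 nM. Compound 2, `Cc1cn2c(/C=N/NC(=N)N)c(-c3ccsc3)nc2s1`, gives 13800 nM. Compound 3, `N=C(N)N/N=C/c1c(-c2ccsc2)nc2n1CCS2`, gives 28800 nM, the highest of the three, and its gaps to compound 1 and compound 2 lie beyond the usual scatter. Compound 2 and compound 1 differ only by 2,5-dimethylthiophen-3-yl in place of thiophen-3-yl on an aromatic carbon, and that change gives a 1.4-fold lower number from compound 2 to compound 1 (0.15 log units; within the scatter). Compound 3 and compound 2 share the same hydrazone group but have different cores; the difference between the two cores is not broken down here. Compound 4, `Cc1cc(-c2nc3n(c2/C=N/NC(=N)N)CCS3)c(C)s1`, is compound 3 with 2,5-dimethylthiophen-3-yl in place of thiophen-3-yl on an aromatic carbon. The surroundings of the place differ: in compound 4 it also lies two ring bonds from two ring atoms that each bear a fused ring, so this is the same kind of change, not the same. For compound 4 an estimated step of a 1.4-fold lower number from compound 3 to compound 4 (0.16 log units; within the scatter) is expected in this assay, resting on the earlier step because a 1.4-fold lower number from compound 2 to compound 1 (0.15 log units; within the scatter) was small. Compound 4 is therefore estimated at 20000 nM, between 9000 nM and 45000 nM.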

Compound 4, concentration for 50% growth inhibition: 17000 nM
Compound 4: middle estimate off by 1.2-fold (0.07 log units), on the high side; the range from low to high includes it.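

In this assay, putting 2,5-dimethylthiophen-3-yl in place of thiophen-3-yl gives a 1.7-fold lower number from compound 3 to compound 4 (0.23 log units; within the scatter), a step too small to count as a real difference on its own. Set beside the earlier step, it agrees with it: the same change on two cores in this assay, a 1.4-fold lower number (0.15 log units; within the scatter) from compound 2 to compound 1 and a 1.7-fold lower number (0.23 log units; within the scatter) from compound 3 to compound 4, 1.2-fold (0.08 log units) apart, within the scatter of two such steps. On these two cores the change therefore carries over as a small step, but two pairs of compounds cannot show that it truly strengthens growth inhibition or that it would behave the same way on a third core.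

The compounds shown leave open whether a longer chain or an amine in place of 2,5-dimethylthiophen-3-yl would give a step beyond the scatter. They also leave open whether such a step would carry from one core to the other.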